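A Propyl to Butyl Step in a Cytotoxic Series

The compounds below may be only part of what the source reports. "The series", "measured", "known", "first", "only" and "open" are said of these compounds alone.

Measured in a functional assay on DU-145 cells (Homo sapiens) for cytotoxicity, read by MTT assay; a higher number here means a weaker inhibitor, a lower number a stronger inhibitor:
- compound 1 `CC(C)=CC[C@@H](OC[C@@H](C)O)C1=CC(=O)c2c(O)ccc(O)c2C1=O`: 14300 nM
- compound 2 `CCC(O)CO[C@H](CC=C(C)C)C1=CC(=O)c2c(O)ccc(O)c2C1=O`: 16400 nM
- compound 3 `CCCC(C)(O)CC(=O)O[C@H](CC=C(C)C)C1=CC(=O)c2c(O)ccc(O)c2C1=O`: 75000 nM

Compound 3 has the highest number of the three, making it the weakest inhibitor measured, with 75000 nM in this assay. Its neighbour compound 4 `CCCCC(C)(O)CC(=O)O[C@H](CC=C(C)C)C1=CC(=O)c2c(O)ccc(O)c2C1=O` has not yet been measured. The change is methyl in place of hydrogen on a saturated chain carbon, four bonds along the chain from an oxygen on a saturated carbon, so methyl replaces hydrogen and the propyl end of the chain becomes butyl.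

Within the data shown here, the closest precedent is a similar chain extension elsewhere, a 1.1-fold higher number from compound 1 to compound 2 (0.06 log units; within the scatter). The larger steps, a 5.2-fold higher number from compound 1 to compound 3 (0.72 log units; beyond the scatter) and a 4.6-fold higher number from compound 2 to compound 3 (0.66 log units; beyond the scatter), involve the exchange of a whole side chain for (2-hydroxy-2-methylpentyl)carbonyl, so they bear on this change only loosely. Among the measured compounds shown here, no measured pair shows this exact change on the carbonyl-bearing chain, so the expectation rests on a single precedent.

No shift beyond the scatter is therefore expected in this assay, and the expected change is a 1.1-fold lower number from compound 3 to compound 4 (0.03 log units; within the scatter). For compound 4 the estimated value is 70000 nM, with an expected range from 32000 nM to 150000 nM.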

Compound 4, half-maximal inhibitory concentration: 76500 nM
Compound 4: the middle estimate sits 1.1-fold (0.04 log units) below what was measured; low and high end bracket the measured number.
By their numbers in this assay, from the lowest: compounds 1 and 2 (each within the scatter of the next); then compounds 3 and 4 (each within the scatter of the next).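

In this assay, among these compounds, methyl in place of hydrogen on a saturated chain carbon, four bonds along the chain from an oxygen on a saturated carbon, gives a 1.0-fold higher number from compound 3 to compound 4 (0.01 log units; within the scatter) and so shows, for the first time on the carbonyl-bearing chain, that the propyl to butyl step leaves the reading within the scatter. The gap to the compounds with the shorter hydroxyalkyl side chains also holds with the longer chain, as a 4.7-fold higher number from compound 2 to compound 4 (0.67 log units; beyond the scatter) and a 5.3-fold higher number from compound 1 to compound 4 (0.73 log units; beyond the scatter) both stay beyond the scatter, as the steps to compound 3 did. Nothing at hand gives a reason for either reading.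

On these data alone, whether a chain longer than butyl would also stay within the scatter in this assay remains open. So does the effect of an amine or a carboxylic acid at the end of this chain.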